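Cyano to hydroxymethyl: the next step in the series

A few compounds are considered here, and "the series" means these few. Any claim that something is new, unique, unknown or untested is made for them only; others in the source may bear on it.

Measured so far in an ADME assay on HEp-2 cells (Homo sapiens) for cytotoxicity; on this read-out higher numbers stand for lower toxicity in this test and lower numbers for higher toxicity in this test
- compound 1 `CC(C)CCn1c(Cn2c(=O)n(C(C)C)c3ccccc32)nc2cc(CNS(C)(=O)=O)ccc21` gives 30800 nM
- compound 2 `CC(C)CCn1c(Cn2c(=O)n(CC(=O)O)c3ccccc32)nc2cc(C(=N)N)ccc21` gives 173000 nM
- compound 3 `CC(C)CCn1c(Cn2c(=O)n(C(C)C)c3ccccc32)nc2ccc(C#N)cc21` gives 10000 nM

Compound 3 stands lowest of the three numbers at 10000 nM in this assay and both other compounds lie beyond the scatter from it. Compound 1 is the nearest at 30800 nM on this scale and compound 2 the furthest at 173000 nM on the same scale. Among the measured compounds shown here, no two measured compounds differ in one place only, so no direct step is available as a guide.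

The next compound to be read is compound 4 `CC(C)CCn1c(Cn2c(=O)n(C(C)C)c3ccccc32)nc2ccc(CO)cc21`, which carries hydroxymethyl in place of cyano on an aromatic carbon of the shared core, with the count of the change as follows: hydroxymethyl in place of cyano on an aromatic carbon. With compound 3 at the bottom of the measured numbers and compound 1 at 30800 nM as the next one up, a small rise in this assay is expected rather than a fall, and it may not clear the scatter. The expected change is a 1.8-fold higher number from compound 3 to compound 4 (0.26 log units; within the scatter) as an estimate, small against the spread of the measured compounds. For compound 4 the estimated value is 18000 nM with an expected range from 7000 nM to 50000 nM for this measurement.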

Compound 4, half-maximal cytotoxic concentration: 81600 nM
Estimate against measurement, compound 4: 4.5-fold (0.66 log units) below; measured number above the stated range.
By their numbers in this assay, from the lowest: compound 3; then compound 1; then compound 4; then compound 2.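

In this assay, among the compounds shown here, hydroxymethyl in place of cyano on an aromatic carbon of the shared core gives an 8.2-fold higher number from compound 3 to compound 4 (0.91 log units; beyond the scatter), the only step here in which a single change can be read. This aromatic carbon, meta to a fused ring and para to a fused ring, is therefore not indifferent to its substituent: the two groups match in heavy-atom count and hydrogen-bond acceptor count, and neither carries a net charge, yet the step lies beyond the scatter, while the counted differences are the hydrogen-bond donor that enters and the triple bond that leaves. No measurement shown here accounts for the higher number, so the step stands as an observation without an established cause.

Still open, from the compounds shown here alone, is whether the donor or the loss of the nitrile goes with the rise, a question that methoxymethyl or aminomethyl on the same carbon would help to separate. Also open, going by these compounds, is whether the step carries over to other substituents on the shared core, as it rests on one pair and compound 1 and compound 2 differ from these two in more than one place.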